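Low-inhibition thioether series at adenosine receptor A3

The source may hold more compounds than are shown below. What is called first, only, known or untested is meant among the compounds shown, and "the series" means these compounds.

Measured so far:
- compound 1, `N#Cc1c(N)nc(SCC(=O)NCO)c(C#N)c1-c1ccc(OCC2CC2)cc1`: 8%
- compound 2, `C=C(C)COc1ccc(-c2c(C#N)c(N)nc(SCC(N)=O)c2C#N)cc1`: 4%
- compound 3, `C=CCOc1ccc(-c2c(C#N)c(N)nc(SCc3ccn[nH]3)c2C#N)cc1`: 13%

All three compounds share the core of compound 1 and differ in the group on the sulfur chain and in the ether on the outer phenyl ring. In an assay on CHO cells for displacement of a labelled ligand from adenosine receptor A3 (Homo sapiens), read by scintillation counting, with a stated time of 120 min, tested at 1 uM (on this read-out higher numbers stand for more inhibition at the one concentration tested (going by the name of the read-out) and lower numbers for less inhibition), compound 1 gives 8%, a number that sits within the usual scatter of compound 2 at 4% and of compound 3 at 13%. On the numbers shown, none of the three can be set apart from the others, and no step between them has been worked out.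

Compound 4, `N#Cc1c(N)nc(SCC2=NCCN2)c(C#N)c1-c1ccc(OCC2CC2)cc1`, is the next compound to be measured. It differs from compound 1 at one place only:
a group of 5 heavy atoms (3 carbon, 2 nitrogen; one five-membered non-aromatic ring with 2 hetero atoms) in place of a group of 5 heavy atoms (2 carbon, 1 nitrogen, 2 oxygen; no ring), on a saturated chain carbon bound to a sulfur
Among the measured compounds shown here, nothing among the measured compounds shows a change of this kind, so its effect has to be estimated from the general picture: every group tried so far on the sulfur chain gives a low read-out in this assay, and nothing indicates that the change to compound 4 would move the number beyond the scatter in either direction. The step from compound 1 is expected to be a number 2 percentage points higher from compound 1 to compound 4 (within the scatter). Compound 4 is therefore estimated at 10%, in the range 0% to 30%.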

Compound 4, a percentage reported as inhibition, at one concentration (the size of the read-out at that concentration, not a potency): 6%
For compound 4 the middle estimate is 4 percentage points above the measured one; measured number inside the range.
By their numbers in this assay, from the lowest: compounds 2, 4, 1 and 3 (each within the scatter of the next).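

In this assay, among the compounds shown here, the only pair that differs in a single place gives a number 2 percentage points lower from compound 1 to compound 4 (within the scatter), so on a saturated chain carbon bound to a sulfur, the (hydroxymethyl)carbamoyl group and the five-membered non-aromatic ring with 2 hetero atoms cannot be told apart. This change keeps the heavy-atom count and the absence of net charge while bringing in a ring and replacing the oxygen-bearing open group with one that holds no oxygen, and neither group gives a read-out that can be separated from the other at the one concentration tested. No measurement is available that would explain this result.

For the compounds shown here, whether a primary amine, a carboxylic acid or a longer chain ending in one of these groups at this position would give a number beyond the scatter remains open, since the present pair covers only one exchange. Going by these compounds, the contribution of the ether on the outer phenyl ring also remains open, as compound 2 and compound 3 differ from compound 1 in more than one place, and a simple methoxy group there would offer a further point of comparison.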